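Swapping Methoxy for a Sulfur-Bearing Group on Compound 1

A few compounds are considered here, and "the series" means these few. Any claim that something is new, unique, unknown or untested is made for them only; others in the source may bear on it.

Of the compounds shown here, three have been tested so far in an ADME assay on Vero cells (Chlorocebus sabaeus) for cytotoxicity, read by MTT assay, with a stated time of 72 h; on this read-out higher numbers stand for lower toxicity in this test and lower numbers for higher toxicity in this test. Compound 1 `CCOC(=O)c1c(-c2ccc(OC)cc2)oc2ccc(OCCCCCCN3C(=O)/C(=N\OC)c4ccccc43)cc12` gives 32 ug/mL in this assay. Compound 3 `CCOC(=O)c1c(-c2ccc(OC)cc2)oc2ccc(OCCCCN3C(=O)/C(=N\OC)c4ccccc43)cc12`, which carries a shorter chain, gives 32 ug/mL, no change from compound 1 at the digits shown. Compound 2 `CCOC(=O)c1c(-c2ccc(F)cc2)oc2ccc(OCCCCCCN3C(=O)/C(=N\OC)c4cc(F)ccc43)cc12` gives 16 ug/mL, the furthest of the three from compound 1 but still within the scatter of repeated measurements. All three numbers therefore sit within the scatter of one another, and no ordering among them can be claimed.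

Compound 4 `CCOC(=O)c1c(-c2ccc(OC)cc2)oc2ccc(OCCCCCCN3C(=O)/C(=N\NC(N)=S)c4ccccc43)cc12` has not yet been measured. It differs from compound 1 at one place: a group of 4 heavy atoms (1 carbon, 2 nitrogen, 1 sulfur; no ring) in place of a group of 2 heavy atoms (1 carbon, 1 oxygen; no ring), on a double-bonded nitrogen. Within the data shown here, no step between measured compounds isolates this kind of change, so the expectation rests only on the narrow spread of the three measured values in this assay.

Compound 4 is expected to give about 32 ug/mL in this assay, with a range from 12 ug/mL to 80 ug/mL. The estimate implies a step of no change at the digits printed from compound 1 to compound 4 (within the scatter), that is, none beyond the scatter.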

Compound 4, half-maximal cytotoxic concentration: 8 ug/mL
Compound 4: middle estimate off by 4.0-fold (0.60 log units), on the high side, outside the stated range (below it).
By their numbers in this assay, from the lowest: compounds 4, 2, 1 and 3 (each within the scatter of the next, the first and the last beyond it).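

In this assay, replacing methoxy on the double-bonded nitrogen with the group of 4 heavy atoms (1 carbon, 2 nitrogen, 1 sulfur) gives a 4.0-fold lower number from compound 1 to compound 4 (0.60 log units; beyond the scatter). Among these compounds, the earlier compounds all carry methoxy at this position, so only this step shows that the position responds to a change of group, here towards higher toxicity in this test, though the step is modest. Nothing measured here accounts for the step.

From the compounds shown here alone, with a single replacement at this position, it remains open whether the sulfur or the rest of the new group goes with the lower number. The same group with oxygen in place of sulfur, or a plain hydroxyl on that nitrogen, would help to separate these, and the step's behaviour with the shorter chain of compound 3 is also unknown.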